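A few compounds are considered here, and "the series" means these few. Any claim that something is new, unique, unknown or untested is made for them only; others in the source may bear on it.

Measured compounds:
compound 1 `NCCNC(=O)c1c(O)c2ccccc2n(-c2ccccc2)c1=O` — 68.1%
compound 2 `Cn1c(=O)c(C(=O)NCCCCCCN)c(O)c2ccccc21` — 68.5%
compound 3 `O=C(CCCCC1CCSS1)NCCNC(=O)c1c(O)c2ccccc2n(-c2ccccc2)c1=O` — 45.5%

In a functional assay on the whole organism (strain Fischer 344) for inhibition, with Rattus norvegicus as the target, read by paw edema, at a dose of 0.01 mmol/kg by the intraperitoneal route (on this read-out lower numbers stand for less inhibition and higher numbers for more inhibition at the one dose given (going by the name of the read-out)), compound 1 gives 68.1% and compound 2 gives 68.5%; these two lie within the scatter of each other, so no order is read between them. Compound 3 gives 45.5% in this assay. Compound 1 and compound 2 carry different cores; the difference between the two cores is not broken down here.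

Compound 3 derives from compound 1 by a group of 11 heavy atoms (8 carbon, 1 oxygen, 2 sulfur; one five-membered non-aromatic ring with 2 hetero atoms) in place of a hydrogen atom, on an amine nitrogen, and this change moved this assay by a number 22.6 percentage points lower from compound 1 to compound 3 (beyond the scatter), a modest step beyond the scatter. Compound 4 `Cn1c(=O)c(C(=O)NCCCCCCNC(=O)CCCCC2CCSS2)c(O)c2ccccc21` is not yet measured. It derives from compound 2 by a group of 11 heavy atoms (8 carbon, 1 oxygen, 2 sulfur; one five-membered non-aromatic ring with 2 hetero atoms) in place of a hydrogen atom, on an amine nitrogen, the same change at the same kind of place, applied on the other core.

Among the compounds with values here, only one measured pair carries this change, so the expectation for compound 4 rests on a number 22.6 percentage points lower from compound 1 to compound 3 (beyond the scatter) alone, without any check on whether the other core responds alike. The step from compound 2 to compound 4 in this assay is expected to be a number 22.5 percentage points lower from compound 2 to compound 4 (beyond the scatter), set beside the earlier step. Within the data shown here, compound 4 is accordingly estimated at 46% in this assay, with a range from 30% to 62% to allow for the single precedent.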

Compound 4, a percentage reported as inhibition, in the whole organism at one dose (the size of the read-out at that dose, not a potency): 53%
The estimate for compound 4 lay 7 percentage points below the measured number; the measured number falls inside the stated range.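

On the core of compound 2, a group with a five-membered non-aromatic ring and sulfur atoms in place of a hydrogen atom on the amine nitrogen gives, in this assay, a number 15.5 percentage points lower from compound 2 to compound 4 (beyond the scatter). Set beside the earlier step, the change lowers the number on both cores, and the two steps cannot be told apart in size: the same change on two cores in this assay, a number 22.6 percentage points lower (beyond the scatter) from compound 1 to compound 3 and a number 15.5 percentage points lower (beyond the scatter) from compound 2 to compound 4, 7.1 percentage points apart, within the scatter of two such steps. This shows that the lowering carried from one core to the other in these two pairs, but it does not show that it would carry to a further core, and a single dose in one assay gives no reason for it.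

Still open, going by these compounds, is whether a plain acetyl group on the same amine nitrogen would lower the number as far, which would separate the effect of the new amide from that of the sulfur-bearing ring. Also open, on these data alone, is whether a longer chain between the amide and the ring would keep the same step on either core.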